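A few compounds are considered here, and "the series" means these few. Any claim that something is new, unique, unknown or untested is made for them only; others in the source may bear on it.

Measured so far:

- compound 1 `Cc1cc(-c2cc(C)c(OC[C@@](C)(N)CC(C)C)cn2)ccn1`: 19 nM
- compound 2 `CC(=O)Nc1cc(-c2ccc(OC[C@@](C)(N)CC(C)C)c(F)c2)ccn1`: 0.8 nM
- compound 3 `COC(=O)Nc1cc(-c2cnc(OC[C@@](C)(N)CC(C)C)c(Cl)c2)ccn1`: 0.4 nM

All three values come from an assay on isolated protein for inhibition of AP2-associated protein kinase 1 (Homo sapiens), with a stated time of 3 h, in the presence of a further agent that is not named here; a higher number here means a weaker inhibitor, a lower number a stronger inhibitor. Among these numbers compound 1 stands highest, so it is the weakest inhibitor of the three; compound 2 sits at a much lower number, and compound 3 at a lower number still, and both gaps lie beyond the scatter. Compound 2 and compound 3 share a feature that compound 1 lacks: a group with an amide hydrogen on the ring that carries the methyl in compound 1.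

Compound 4 `COC(=O)Nc1cc(-c2cc(C)c(OC[C@@](C)(N)CC(C)C)cn2)ccn1` has not yet been measured. It differs from compound 1 in one place: (methoxycarbonyl)amino in place of methyl on an aromatic carbon. Among the compounds with values here, no measured pair shows this exact change alone, since compound 2 and compound 3 also differ from compound 1 elsewhere. Still, a substantial step toward a lower number is expected in this assay, in view of compound 2 with 0.8 nM and compound 3 with 0.4 nM. Compound 4 is therefore estimated at 1.5 nM, in a range from 0.4 nM to 6 nM, a step of a 13-fold lower number from compound 1 to compound 4 (1.10 log units; beyond the scatter) expected.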

Compound 4, half-maximal inhibitory concentration: 1.7 nM
Compound 4: middle estimate off by 1.1-fold (0.05 log units), on the low side; measured number inside the range.
By their numbers in this assay, from the lowest: compounds 3 and 2 (each within the scatter of the next); then compound 4; then compound 1.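

In this assay, putting (methoxycarbonyl)amino in place of methyl on an aromatic carbon, next to the ring nitrogen, gives an 11-fold lower number from compound 1 to compound 4 (1.05 log units; beyond the scatter), a large step. Within the data shown here, compound 2 and compound 3 carry other differences from compound 1, so this pair is the first to show the effect of this change alone, with the rest of the core held constant. No measurement here explains why the step is this large.

The compounds shown leave open how much of the step depends on each part of the entering group, which a plain amine at this place could help to test. From the compounds shown here alone, it also remains open whether a longer chain on the oxygen, such as ethoxycarbonylamino in place of (methoxycarbonyl)amino, would keep the number this low.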